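The compounds below may be only part of what the source reports. "The series", "measured", "known", "first", "only" and "open" are said of these compounds alone.

Compound 1 `C/N=C(\S)n1nc(-c2ccccc2)nc1N` stands highest of the two measured compounds: in a functional assay on the whole organism for inhibition, with Rattus norvegicus as the target, at a dose of 30 mg/kg (on this read-out higher numbers stand for more inhibition at the one dose given (going by the name of the read-out) and lower numbers for less inhibition), compound 1 gives 54%, while compound 2 `C/N=C(\S)Nc1ccc(-c2nc(N)n(/C(S)=N/C)n2)cc1` gives 31% in this assay. For the measured compounds named here, the only measured step joins these two compounds: a number 23 percentage points lower from compound 1 to compound 2 (beyond the scatter), where a larger group replaces a hydrogen atom on an aromatic carbon. Compound 3 `C/N=C(\S)n1nc(-c2cccc(Cl)c2)nc1N` has not been measured yet. It differs from compound 1 by chloro in place of hydrogen on an aromatic carbon, on an aromatic carbon of a six-membered aromatic ring of carbon only, meta to a large group. Going by the values given here, no measured step shows a chloro group entering in this way, so the only guidance is the step from compound 1 to compound 2, a modest drop after a much larger group entered at an aromatic carbon. Chloro is a far smaller addition, so a drop of that size is not expected; a small downward shift, or none beyond the scatter, seems most likely. The expected step is a number 6 percentage points lower from compound 1 to compound 3 (within the scatter). Compound 3 is therefore estimated to give 48% in this assay, with a likely range from 30% to 65%.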

Compound 3, a percentage reported as inhibition, in the whole organism at one dose (the size of the read-out at that dose, not a potency): 54%
Compound 3: the middle estimate sits 6 percentage points below what was measured; measured number inside the range.
By their numbers in this assay, from the lowest: compound 2; then compounds 1 and 3 (each within the scatter of the next).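

In this assay, chloro in place of hydrogen on an aromatic carbon, meta to a large group, gives no change at the digits printed from compound 1 to compound 3 (within the scatter), so this position of the ring takes a chlorine atom with no shift beyond the usual scatter. For the compounds shown here, the only earlier step, a number 23 percentage points lower from compound 1 to compound 2 (beyond the scatter), came with a much larger group entering on an aromatic carbon, and the new result shows that such a drop does not follow from every addition to this ring. Nothing available here explains why the number stays where it is, and no measurement of any property of these compounds bears on it.

The compounds shown leave open whether a different group at this same place, such as methoxy, an amine or a carboxylic acid, would keep the number level as chloro does, or whether a group in size between chloro and the large group of compound 2 would start to lower it. They also leave open whether chloro on another carbon of this ring would give the same result, since this single case cannot speak for the whole ring.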